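The compounds below may be only part of what the source reports. "The series", "measured", "known", "first", "only" and "open" are said of these compounds alone.

Compound 1, `Cc1n[nH]c2nc(-c3ccc(NS(=O)(=O)c4cc(Cl)ccc4F)cc3)nc(OCCC(=O)N(C)C)c12`, gives 15 nM in an assay for inhibition of serine/threonine-protein kinase Sgk1 (Homo sapiens), with stated times of 30 min and 60 min, in the presence of a further agent that is not named here; on this read-out higher numbers stand for weaker inhibition and lower numbers for stronger inhibition.
Compound 2, `Cc1n[nH]c2nc(-c3ccc(NS(=O)(=O)c4cc(Cl)ccc4F)cc3)nc(OCC3CN(C(C)C)C3)c12`, gives 1 nM in this assay.
Compound 3, `Cc1n[nH]c2nc(-c3ccc(NS(=O)(=O)c4cc(Cl)ccc4F)cc3)nc(OCC3CNCCO3)c12`, gives 2 nM in this assay.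

Compound 3 stands second highest of the three numbers. Its nearest neighbour is compound 2, and that pair shows a 2.0-fold higher number from compound 2 to compound 3 (0.30 log units; within the scatter). The further neighbour is compound 1, and that pair shows a 7.5-fold lower number from compound 1 to compound 3 (0.88 log units; beyond the scatter).

Compound 4, `Cc1n[nH]c2nc(-c3ccc(NS(=O)(=O)c4cc(Cl)ccc4F)cc3)nc(OC3CC(C)(C)N(C)C(C)(C)C3)c12`, has not yet been measured. It differs from compound 3 in one place: 1,2,2,6,6-pentamethylpiperidin-4-yl in place of (morpholin-2-yl)methyl on an oxygen on an aromatic ring. Within the data shown here, two measured steps bear on this change. The move from compound 1 to compound 3 exchanged a (dimethylcarbamoyl)methyl group for a ring bearing a nitrogen and gave a modest step; the move from compound 2 to compound 3 exchanged one nitrogen-bearing saturated ring for another and stayed within the scatter. The group entering in compound 4, like the 1-isopropylazetidin-3-yl group of compound 2, is a saturated ring whose nitrogen carries an alkyl group, so a small step at most is expected in this assay, in either direction or none beyond the scatter. Compound 4 is therefore estimated at 2 nM, with a range from 0.7 nM to 6 nM, which corresponds to an expected step of no change at the digits printed from compound 3 to compound 4 (within the scatter).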

Compound 4, half-maximal inhibitory concentration: 2 nM
The estimate for compound 4 equals the measured number at the digits printed; the range from low to high includes it.
By their numbers in this assay, from the lowest: compounds 2, 3 and 4 (each within the scatter of the next); then compound 1.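

In this assay, placing 1,2,2,6,6-pentamethylpiperidin-4-yl on the oxygen shows that this position accepts a ring bound directly to the oxygen, with no saturated chain carbon in between, and the reading stays level with the two earlier ring-bearing compounds: there is no change at the digits printed from compound 3 to compound 4 (within the scatter) and a 2.0-fold higher number from compound 2 to compound 4 (0.30 log units; within the scatter). The same exchange also shows that the hydrogen-bond donor counted on the (morpholin-2-yl)methyl group is not required to hold that level, and that the larger group, with more heavy atoms than the one it replaces, is accommodated here; against the 2-(dimethylcarbamoyl)ethyl group the change gives a 7.5-fold lower number from compound 1 to compound 4 (0.88 log units; beyond the scatter), so compound 1 alone stands apart from the three compounds with a nitrogen-bearing saturated ring. No supporting evidence is available to explain this result.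

The compounds shown leave open whether a ring nitrogen is needed at all, as a plain cyclohexyl ring on the same oxygen would test. Also open, as far as these compounds go, is how a carboxylic acid at this place, or the piperidin-4-yl ring without its methyl groups, would read in this assay.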